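Swapping the benzyl group of compound 2

The compounds below may be only part of what the source reports. "The series", "measured", "known", "first", "only" and "open" are said of these compounds alone.

Measured in a functional assay on HT-29 cells (Homo sapiens) for cytotoxicity, read by MTT assay; on this read-out higher numbers stand for weaker inhibition and lower numbers for stronger inhibition:
compound 1 `CC(=O)O[C@@H]1OC(=O)[C@](C)(C(C)=O)[C@@H]1C` gives 5000 nM
compound 2 `CC(=O)O[C@@H]1OC(=O)[C@](Cc2ccccc2)(C(C)=O)[C@@H]1C` gives 40000 nM
compound 3 `CC(=O)CC[C@]1(C(C)=O)C(=O)O[C@@H](OC(C)=O)[C@H]1C` gives 7000 nM

Compound 2 has the highest number of the three and is the weakest here. The steps that set it apart, an 8.0-fold higher number from compound 1 to compound 2 (0.90 log units; beyond the scatter) and a 5.7-fold lower number from compound 2 to compound 3 (0.76 log units; beyond the scatter), are both modest but beyond the scatter. Compound 4 `CC(=O)O[C@@H]1OC(=O)[C@@](C(C)=O)(C2SCCCS2)[C@@H]1C` has not yet been measured. The change that leads to it is a group of 6 heavy atoms (4 carbon, 2 sulfur; one six-membered non-aromatic ring with 2 hetero atoms) in place of a group of 7 heavy atoms (7 carbon; one six-membered aromatic ring of carbon only), on a saturated ring carbon, on a saturated ring carbon. These two steps bear on it, since each involves the benzyl-bearing compound 2. The remaining step, a 1.4-fold higher number from compound 1 to compound 3 (0.15 log units; within the scatter), lies within the scatter. For the measured compounds named here, compounds without the phenyl thus sit close together, but none of the measured compounds carries the sulfur-containing ring, so this is only a weak guide. A modest move away from the high number of compound 2 is expected, of similar or smaller size than those two steps. The expected step is a 3.3-fold lower number from compound 2 to compound 4 (0.52 log units; beyond the scatter), a lower number. The estimate for compound 4 is 12000 nM, with an expected range from 3000 nM to 50000 nM.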

Compound 4, half-maximal inhibitory concentration: > 50000 nM
Compound 4: only a limit was reported; the forecaster's own chance of this, stated with the estimate: 10%; at least 4.1-fold (0.61 log units) between middle value and limit.
By their numbers in this assay, from the lowest: compounds 1 and 3 (each within the scatter of the next); then compound 2. At a limit, above all of these: compound 4.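

Compound 4 is reported only as a limit: the limit of > 50000 nM in this assay, at which 1 of the 4 values shown sits. Against the compounds without benzyl the gap is clear, with an at least 10-fold higher number from compound 1 to compound 4 (1.00 log units; beyond the scatter) and an at least 7.1-fold higher number from compound 3 to compound 4 (0.85 log units; beyond the scatter), so this saturated ring carbon does not treat all its groups alike, and losing the aromatic ring of benzyl did not by itself bring the number down. Against benzyl itself the limit separates little, with an at least 1.2-fold higher number from compound 2 to compound 4 (0.09 log units; that floor lies within the scatter), so the non-aromatic ring with 2 sulfur atoms did not recover the lower numbers of compound 1 and compound 3.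

As far as these compounds go, whether a plain pentyl chain or an amine on this ring carbon would sit with compound 1 and compound 3 or with compound 2 and compound 4 stays open. From the compounds shown here alone, how far compound 4 really lies from compound 2 also stays open.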